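This account rests on a few compounds, and the source may have more. Where it says the series, first, only, none or still open, it means among the compounds named here.

Compound 3 has the structure `CCN1CCN(CC(=O)Nc2ccc(-c3nc(-c4ccccc4)c(-c4ccccc4)n3C)cc2)CC1`. In a functional assay on MCF7 cells (Homo sapiens) for cytotoxicity, read by MTT assay, with a stated time of 24 h, tested at 16 ug/mL (on this read-out higher numbers stand for a stronger effect at the one concentration tested and lower numbers for a weaker effect), compound 3 gives 32.8%, the lowest of the three numbers measured. Its neighbours are compound 2, `Cn1c(-c2ccc(NC(=O)CSC3=NCCS3)cc2)nc(-c2ccccc2)c1-c1ccccc1`, which gives 41.8%, and compound 1, `Cn1c(-c2ccc(NC(=O)CSc3nc4ccccc4o3)cc2)nc(-c2ccccc2)c1-c1ccccc1`, which gives 56%. The step of a number 9 percentage points lower from compound 2 to compound 3 (within the scatter) lies within the scatter, while the step of a number 23.2 percentage points lower from compound 1 to compound 3 (beyond the scatter) is beyond it; compound 1 is the only one of the three that carries a six-membered aromatic ring of carbon only in the chain attached to the carbonyl.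

Compound 4, `Cn1c(-c2ccc(NC(=O)CN3CCN(Cc4ccc(Cl)cc4)CC3)cc2)nc(-c2ccccc2)c1-c1ccccc1`, keeps the piperazine of compound 3 and changes only its far end: 4-chlorophenyl in place of methyl on a saturated chain carbon bound to an amine nitrogen in a ring. Within the data shown here, no measured step touches this exact spot; the steps of a number 14.2 percentage points lower from compound 1 to compound 2 (beyond the scatter) and a number 23.2 percentage points lower from compound 1 to compound 3 (beyond the scatter) alter the group on the carbon next to the carbonyl, not the group on the ring nitrogen, so they bear on compound 4 only loosely. They show that exchanging groups in this chain moved the read-out by modest amounts in both directions, with the aromatic ring of compound 1 giving the highest number. A modest rise is therefore expected, with wide uncertainty, as the step of a number 9.2 percentage points higher from compound 3 to compound 4 (within the scatter). Compound 4 is estimated at 42% in this assay, within 25% to 60%.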

Compound 4, a percentage reported as activity, at one concentration (the size of the read-out at that concentration, not a potency): 46.2%
Estimate against measurement, compound 4: 4.2 percentage points below, and the stated range covers the measured number.
By their numbers in this assay, from the lowest: compounds 3, 2, 4 and 1 (each within the scatter of the next, the first and the last beyond it).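

In this assay, the exchange of methyl for 4-chlorophenyl on a saturated chain carbon bound to an amine nitrogen in a ring gives a number 13.4 percentage points higher from compound 3 to compound 4 (beyond the scatter), so the read-out responds to a change at this far end of the chain. Among these compounds, the earlier steps replaced the whole group on the carbon bound to the carbonyl, whereas here the piperazine stays in place and only the group on its far nitrogen differs, which makes this the first measured step to isolate that spot. No measurement shown here explains why this exchange raises the number.

The compounds shown leave open whether the rise belongs to the phenyl ring itself or to its chlorine, a question that a plain phenyl or a 4-methoxyphenyl in the same place would help to settle. They also leave open how this exchange would read at other concentrations, since a single number at one concentration gives the size of an effect and not a potency.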